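A few compounds are considered here, and "the series" means these few. Any claim that something is new, unique, unknown or untested is made for them only; others in the source may bear on it.

Compound 3 `O=C(O)c1cc2cc(-c3ccccc3)n(O)c2cc1C(=O)O` stands at the top of the three numbers in hand: in an assay on isolated protein for inhibition of Amine oxidase [flavin-containing] A (Homo sapiens), read by fluorescence and spectrophotometry, with a stated time of 20 min (on this read-out higher numbers stand for weaker inhibition and lower numbers for stronger inhibition), compound 3 gives 23300 nM. Compound 1 `COc1ccc(-c2cc3cc(C#N)c(C#N)cc3n2O)cc1` sits nearest to it, and in this assay compound 1 gives 1840 nM, a gap beyond the scatter. Compound 2 `COc1ccc(-c2c(C=O)c3cc(C#N)c(C#N)cc3n2OC)cc1` lies furthest away, and in this assay compound 2 gives 147 nM. Going by the values given here, compounds 1 and 2 each differ from compound 3 in more than one place, so their numbers show only that compound 3 is the weakest inhibitor of the three, with no single change to credit.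

Compound 4 `COc1ccc(-c2cc3cc(C(=O)O)c(C(=O)O)cc3n2O)cc1` differs from compound 3 in one place: methoxy in place of hydrogen on an aromatic carbon, para to a large group. Among the compounds with values here, no measured pair shows this change on its own. The account therefore expects only a small step in this assay, toward a lower number if anything, and possibly none beyond the scatter, written as a 1.9-fold lower number from compound 3 to compound 4 (0.29 log units; within the scatter). Compound 4 is expected to give about 12000 nM, within a range from 4000 nM to 40000 nM.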

Compound 4, half-maximal inhibitory concentration: > 100000 nM
Compound 4: only a limit was reported; the forecaster's own chance of this, stated with the estimate: 10%; middle value at least 8.3-fold (0.92 log units) from the limit.
By their numbers in this assay, from the lowest: compound 2; then compound 1; then compound 3. At a limit, above all of these: compound 4.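

Going by these compounds alone, the change from phenyl to 4-methoxyphenyl is the first single change that can be read in this set, and it goes toward weaker inhibition, with an at least 4.2-fold higher number from compound 3 to compound 4 (0.63 log units; beyond the scatter) as its step. With both carboxylic acid groups on the core, methoxy at this place, para to a large group, therefore brings no gain and costs inhibition beyond the scatter. Compound 4 gives > 100000 nM in this assay and that value is a limit of the assay, not a number, so the true size of the step stays unknown and only its lower bound can be read: the limit of > 100000 nM in this assay, at which 1 of the 4 values shown sits.

Going by these compounds, whether methoxy has the same effect on a core carrying nitrile groups in place of the carboxylic acid groups remains open. So does the outcome of putting a different group here, such as fluorine, an amine or a longer chain.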